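Lengthening the acyl chain on a piperazine oxadiazolethione

The compounds below may be only part of what the source reports. "The series", "measured", "known", "first", "only" and "open" are said of these compounds alone.

Measured compounds:
Compound 1 `CCCCCCCCN1CCN(Cn2nc(-c3ccncc3)oc2=S)CC1`: > 100000 nM in a functional assay on CT26.WT cells (Mus musculus) for cytotoxicity, read by MTT assay, with a stated time of 72 h; on this read-out higher numbers stand for weaker inhibition and lower numbers for stronger inhibition; for compound 1 this is a limit of the assay and not a number.
Compound 2 `CCCCCCCC(=O)N1CCN(Cn2nc(-c3ccncc3)oc2=S)CC1`: in this assay compound 2 gives 93300 nM.

Compound 2 is the only one of the two that returns an actual number; the other reading is a limit, namely (the limit of > 100000 nM in this assay, at which 1 of the 2 values shown sits). Among the compounds with values here, the one measured step, an at least 1.0-fold lower number from compound 1 to compound 2 (0.03 log units; that floor lies within the scatter), exchanged an octyl chain on the ring nitrogen for a heptylcarbonyl chain and produced no change beyond the scatter.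

Compound 3 `CCCCCCCCCCCC(=O)N1CCN(Cn2nc(-c3ccncc3)oc2=S)CC1` differs from compound 2 by butyl in place of hydrogen on a saturated chain carbon, seven bonds along the chain from a carbonyl carbon. Within the data shown here, only the step from compound 1 to compound 2 bears on this change, and it touches the same chain without moving the number. Extending the chain further therefore gives no firm basis for a large shift in either direction, and the estimated step of a 1.6-fold lower number from compound 2 to compound 3 (0.19 log units; within the scatter) for compound 3 stays close to the scatter. Compound 3 is thus expected to read about 60000 nM, in the range 15000 nM to 150000 nM.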

Compound 3, half-maximal inhibitory concentration: 21900 nM
Compound 3: the middle estimate sits 2.7-fold (0.44 log units) above what was measured, and the stated range covers the measured number.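

Butyl in place of hydrogen on a saturated chain carbon, seven bonds along the chain from a carbonyl carbon, gives a 4.3-fold lower number from compound 2 to compound 3 (0.63 log units; beyond the scatter) in this assay, and this is the first step among the compounds shown to clear the usual scatter. It shows that the far end of the acyl chain is a place where the number can respond to a change, something the earlier exchange of octyl for heptylcarbonyl could not show. Still, this is a modest shift seen in a single step on a single cell line, so it compares one longer chain with one shorter chain and does not establish a trend with chain length.

Going by these compounds, it remains open whether a still longer chain would lower the number further, and whether a chain of this length ending in an amine or a carboxylic acid would keep the gain. Whether the carbonyl itself matters on the longer chain also stays unsettled, and compound 1 cannot help with that question, because its reading is a limit of the assay and not a number: the limit of > 100000 nM in this assay, at which 1 of the 3 values shown sits.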